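This account rests on a few compounds, and the source may have more. Where it says the series, first, only, none or still open, it means among the compounds named here.

Measured so far:
compound 1, `COc1cc2c(Nc3nc4ccc(C(=O)Nc5c(C)cccc5C)cc4s3)ncnc2cc1OCCCN1CCCCC1` — 13700 nM
compound 2, `COc1cc2c(Nc3nc4ccc(C(=O)Nc5c(C)cccc5Cl)cc4s3)ncnc2cc1OCCCN1CCCC1` — 13300 nM

In a functional assay on K562 cells (Homo sapiens) for cytotoxicity, read by WST assay, with a stated time of 72 h (a lower number here means a stronger inhibitor, a higher number a weaker inhibitor), compound 2 gives 13300 nM, and compound 1 gives 13700 nM; the two numbers sit within the scatter of each other, so neither stands apart. Compound 3, `COc1cc2c(Nc3nc4ccc(C(=O)Nc5c(C)cccc5Cl)cc4s3)ncnc2cc1OCCCN1CCCCC1`, differs from compound 2 only by piperidin-1-yl in place of pyrrolidin-1-yl on a saturated chain carbon, three bonds along the chain from an oxygen on an aromatic ring. Among the compounds with values here, no measured pair shows this change alone. The value of compound 1, which carries the same amine ring as compound 3, lies close to that of compound 2, so the expected step of a 1.0-fold higher number from compound 2 to compound 3 (0.01 log units; within the scatter) is none beyond the scatter. Compound 3 is therefore expected at 13500 nM, within 6500 nM to 28000 nM.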

Compound 3, half-maximal inhibitory concentration: 12500 nM
For compound 3 the middle estimate is 1.1-fold (0.03 log units) above the measured one; low and high end bracket the measured number.
By their numbers in this assay, from the lowest: compounds 3, 2 and 1 (each within the scatter of the next).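

In this assay, within the data shown here, piperidin-1-yl in place of pyrrolidin-1-yl on the saturated chain carbon gives a 1.1-fold lower number from compound 2 to compound 3 (0.03 log units; within the scatter), the first reading of this change alone. Chloro in place of methyl on an aromatic carbon gives a 1.1-fold lower number from compound 1 to compound 3 (0.04 log units; within the scatter), so neither change separates the compounds at this level of activity. No supporting measurement bears on these results.

From the compounds shown here alone, whether a morpholine or an open-chain dimethylamine at the chain end would move the number remains open. So does the effect of methoxy or a carboxylic acid in place of the chloro or methyl group.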